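From iodo to bromo at the limit of the assay

The source may hold more compounds than are shown below. What is called first, only, known or untested is meant among the compounds shown, and "the series" means these compounds.

Compound 1 `COc1cc(O)c(C(=O)/C=C/c2ccccc2)cc1I` gives > 50000 nM as a limit
Compound 2 `CCCOc1ccc(C(=O)/C=C/c2ccccc2)c(O)c1` gives 8080 nM as a number

Both results come from a functional assay on PC-3 cells (Homo sapiens) for antiproliferative activity, with a stated time of 48 h (on this read-out lower numbers stand for stronger inhibition and higher numbers for weaker inhibition), and only compound 2 has a number. Compound 1 stands at the limit of > 50000 nM in this assay, at which 1 of the 2 values shown sits, and this is a limit, not a number. Compound 3 `COc1cc(O)c(C(=O)/C=C/c2ccccc2)cc1Br` carries bromo in place of iodo on an aromatic carbon on the core of compound 1, bromo in place of iodo on an aromatic carbon. For the measured compounds named here, no measured pair tests this exchange, so in this assay a small step of an at least 1.6-fold lower number from compound 1 to compound 3 (0.22 log units; that floor lies within the scatter) is expected, toward stronger inhibition if any. For compound 3 the estimated value is 30000 nM with an expected range from 10000 nM to 70000 nM in that read-out.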

Compound 3, half-maximal inhibitory concentration: > 50000 nM
Compound 3 ended at the assay's limit; the forecaster's own chance of this, stated with the estimate: 55%; middle value at least 1.6-fold (0.22 log units) away from the limit.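

Compound 1 and compound 3 both stand at a limit in this assay, so the step between them cannot be read. From the compounds shown here alone, whether bromo and iodo differ at all on the shared core in this assay stays open.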